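This account rests on a few compounds, and the source may have more. Where it says the series, first, only, none or still open, it means among the compounds named here.

Measured compounds:
compound 1 `CCNc1nc(-c2ccccc2)nc2c1nnn2Cc1ccccc1Cl` — 463 nM
compound 2 `CCNc1nc(-c2ccccc2)nc2c1nnn2Cc1ccccc1F` — 11 nM
compound 3 `CCCCCCNc1nc(-c2ccccc2)nc2c1nnn2Cc1ccccc1Cl` — 31 nM

In an assay on Cerebral cortex for displacement of a labelled ligand from adenosine receptor A1 (Bos taurus) (a lower number here means a stronger inhibitor, a higher number a weaker inhibitor), compound 1 gives 463 nM. Compound 2 carries fluoro in place of chloro on an aromatic carbon and in this assay compound 2 gives 11 nM, a step of a 42-fold lower number from compound 1 to compound 2 (1.62 log units; beyond the scatter). Compound 3 differs from compound 1 by butyl in place of hydrogen on a saturated chain carbon, two bonds along the chain from a nitrogen on an aromatic ring; in this assay compound 3 gives 31 nM, a step of a 15-fold lower number from compound 1 to compound 3 (1.17 log units; beyond the scatter). Compound 4 `CCCCCCNc1nc(-c2ccccc2)nc2c1nnn2Cc1ccccc1F` is not yet measured and differs from compound 3 by fluoro in place of chloro on an aromatic carbon, the same change as that from compound 1 to compound 2. For compound 4 a step of a 10-fold lower number from compound 3 to compound 4 (1.01 log units; beyond the scatter) is expected in this assay because a 42-fold lower number from compound 1 to compound 2 (1.62 log units; beyond the scatter) was large, though it rests on one pair only and may not carry over in full. Compound 4 is estimated at 3 nM, with a likely range from 0.7 nM to 15 nM.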

Compound 4, inhibition constant: 25 nM
Beside the measured number, compound 4's estimate is 8.3-fold (0.92 log units) below it; measured number outside the range, above it.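

In this assay, fluoro in place of chloro on an aromatic carbon gives a 1.2-fold lower number from compound 3 to compound 4 (0.09 log units; within the scatter), so the large step seen on the core of compound 1 does not recur on the core of compound 3: the same change on two cores in this assay, a 42-fold lower number (1.62 log units; beyond the scatter) from compound 1 to compound 2 and a 1.2-fold lower number (0.09 log units; within the scatter) from compound 3 to compound 4, 34-fold (1.53 log units) apart, beyond the scatter of two such steps Butyl in place of hydrogen on the chain gives a 2.3-fold higher number from compound 2 to compound 4 (0.36 log units; beyond the scatter), which runs in the opposite direction to the step between the two chloro compounds: the same change on two cores in this assay, a 15-fold lower number (1.17 log units; beyond the scatter) from compound 1 to compound 3 and a 2.3-fold higher number (0.36 log units; beyond the scatter) from compound 2 to compound 4, 34-fold (1.53 log units) apart, beyond the scatter of two such steps The two changes therefore do not add up across these four compounds, and the size of each depends on the other; this does not show why, or how either change would behave on any other core.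

The compounds shown leave open whether bromo or methyl in place of the halogen, or a longer chain, would follow the same pattern.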